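Swapping an aryl group for an anilino link

The source may report more compounds than this note shows. Statements on the series, on what has been measured and on what is new or still open speak of the compounds shown alone.

Values in a functional assay on Jurkat cells (Homo sapiens) for antiproliferative activity, read by MTT assay, with a stated time of 72 h; a lower number here means a stronger inhibitor, a higher number a weaker inhibitor:
Compound 1 `COc1cc(C(=O)c2sc3ccccc3c2-c2ccc(SC)cc2)cc(OC)c1OC`: 1900 nM
Compound 2 `COc1ccc(-c2c(C(=O)c3cc(OC)c(OC)c(OC)c3)sc3ccccc23)cc1C`: > 10000 nM (a limit of the assay, not a number)
Compound 3 `CCOc1ccc(-c2c(C(=O)c3cc(OC)c(OC)c(OC)c3)sc3ccccc23)cc1`: 4100 nM

Within the data shown here, only two of these values are exact numbers, and compound 3 has the higher one, 4100 nM. The nearest exact value shows a 2.2-fold higher number from compound 1 to compound 3 (0.33 log units; beyond the scatter). Compound 2 is reported only as a limit, > 10000 nM.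

Compound 4 `COc1cc(C(=O)c2sc3ccccc3c2Nc2ccc(Cl)cc2)cc(OC)c1OC` carries (4-chlorophenyl)amino in place of 4-ethoxyphenyl, on an aromatic carbon of a five-membered aromatic ring with 1 sulfur: (4-chlorophenyl)amino in place of 4-ethoxyphenyl on an aromatic carbon. The measured steps only exchange groups on the phenyl ring: an at least 5.2-fold higher number from compound 1 to compound 2 (0.72 log units; beyond the scatter), and an at least 2.4-fold lower number from compound 2 to compound 3 (0.38 log units; beyond the scatter). None of them introduces an amino link, so they offer only a loose guide, and they point in no single direction for this change. In this assay, no step beyond the scatter is therefore expected: a 1.4-fold lower number from compound 3 to compound 4 (0.14 log units; within the scatter). Compound 4 is estimated at 3000 nM, with an expected range from 500 nM to 10000 nM.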

Compound 4, half-maximal inhibitory concentration: 1900 nM
Compound 4: the middle estimate sits 1.6-fold (0.20 log units) above what was measured; measured number inside the range.
By their numbers in this assay, from the lowest: compounds 1 and 4 (each within the scatter of the next); then compound 3. At a limit, above all of these: compound 2.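

In this assay, this position of the five-membered ring accepts an amino link in place of a directly attached aryl group: swapping in (4-chlorophenyl)amino, which adds a hydrogen-bond donor, gives a 2.2-fold lower number from compound 3 to compound 4 (0.33 log units; beyond the scatter). Set against the 4-(methylsulfanyl)phenyl group, the same link shows no change at the digits printed from compound 1 to compound 4 (within the scatter), so the two kinds of attachment can give matching numbers here. The comparison with the 4-methoxy-3-methylphenyl group shows an at least 5.2-fold lower number from compound 2 to compound 4 (0.72 log units; beyond the scatter), but that gives only a minimum size for the step, as compound 2 is reported as a limit: the limit of > 10000 nM in this assay, at which 1 of the 4 values shown sits.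

The amino link and the chlorine arrive together, so these compounds cannot separate their contributions. Open questions are how a plain phenylamino group would compare, and whether a methyl group on the link nitrogen would keep the number.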